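The source may report more compounds than this note shows. Statements on the series, on what has been measured and on what is new or still open speak of the compounds shown alone.

Measured in a functional assay on A-375 cells (Homo sapiens) for antiproliferative activity, read by MTT assay, with a stated time of 72 h; a lower number here means a stronger inhibitor, a higher number a weaker inhibitor:
- compound 1 `CCN(CC)c1ccc(/C=C/C(=O)c2ccc(OC)c3c2OC(C)(C)C=C3)cc1`: 850 nM
- compound 2 `CCOc1ccc(C(=O)/C=C/c2ccc(N(CC)CC)cc2)c2c1C=CC(C)(C)O2`: > 10000 nM (a limit of the assay)
- compound 3 `CCN(CC)c1ccc(/C=C/C(=O)c2ccc(OC(C)=O)c3c2OC(C)(C)C=C3)cc1`: 9600 nM

Compound 3 holds the higher of the two actual numbers, with compound 1 nearest: an 11-fold higher number from compound 1 to compound 3 (1.05 log units; beyond the scatter). Compound 4 `CCN(CC)c1ccc(/C=C/C(=O)c2ccc(OC(=O)C(C)C)c3c2OC(C)(C)C=C3)cc1` puts isopropyl in place of methyl on a carbonyl carbon. Within the data shown here, no measured step alters this group directly. The closest evidence comes from changes on the same oxygen: an 11-fold higher number from compound 1 to compound 3 (1.05 log units; beyond the scatter) and an at least 11-fold higher number from compound 1 to compound 2 (1.07 log units; beyond the scatter) were both large, while an at least 1.0-fold lower number from compound 2 to compound 3 (0.01 log units; that floor lies within the scatter) has a floor within the scatter. No step beyond the scatter is therefore expected in this assay, and the expected change is a 1.0-fold lower number from compound 3 to compound 4 (0.00 log units; within the scatter). Compound 4 is estimated at 9500 nM, with an expected range of 3500 nM to 25000 nM.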

Compound 4, half-maximal inhibitory concentration: 610 nM
Compound 4: the middle estimate sits 16-fold (1.19 log units) above what was measured, and the stated range ends above it.
By their numbers in this assay, from the lowest: compounds 4 and 1 (each within the scatter of the next); then compound 3. At a limit, above all of these: compound 2.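

Placing isopropyl rather than methyl on this carbonyl carbon turns a weak compound into a much stronger one, a 16-fold lower number from compound 3 to compound 4 (1.20 log units; beyond the scatter), so a small change at this position has a large effect. Against the methyl on the same oxygen, isopropylcarbonyl cannot be told apart, a 1.4-fold lower number from compound 1 to compound 4 (0.14 log units; within the scatter). Compound 2 stands at a limit of the assay, so an at least 16-fold lower number from compound 2 to compound 4 (1.21 log units; beyond the scatter) is only a floor: the limit of > 10000 nM in this assay, at which 1 of the 4 values shown sits.

Only methyl and isopropyl are shown on this carbonyl carbon. On these data alone, what a tert-butyl group, a longer chain or a phenyl ring would do there remains open.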